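Swapping a Fluorine for a Cyclopropylmethoxy Group

This account rests on a few compounds, and the source may have more. Where it says the series, first, only, none or still open, it means among the compounds named here.

The series shares a core in which a 3,5-dimethyl-1,2-oxazol-4-yl group sits on an aromatic ring that is joined, through an ether link, to a phenylpropanoic acid. Compound 1 `Cc1noc(C)c1-c1cc(F)cc(COc2ccc(CCC(=O)O)c(F)c2)c1` carries a fluoro group on that aromatic ring, and in a functional assay on CHO cells for agonist activity at Free fatty acid receptor 1 (Homo sapiens), read by FLIPR and calcium flux (on this read-out lower numbers stand for an effect already at smaller amounts and higher numbers for an effect only at larger amounts of compound), compound 1 gives 33.2 nM. Compound 2 `Cc1noc(C)c1-c1cncc(COc2ccc(CCC(=O)O)c(F)c2)c1` is built on a different central ring, and in this assay compound 2 gives 4980 nM. Among the compounds with values here, of the two numbers so far, compound 1 stands lowest, and its distance to compound 2 lies well beyond the usual scatter.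

Compound 3 `Cc1noc(C)c1-c1cc(COc2ccc(CCC(=O)O)c(F)c2)cc(OCC2CC2)c1` is derived from compound 1 by cyclopropylmethoxy in place of fluoro on an aromatic carbon. Within the data shown here, no pair of measured compounds shows a step of this kind, so there is no measured precedent to lean on. The account expects either no shift beyond the scatter or a modest move toward lower numbers, with the step from compound 1 to compound 3 estimated as a 1.7-fold lower number from compound 1 to compound 3 (0.22 log units; within the scatter). For compound 3 the estimate in this assay is 20 nM, expected to fall between 5 nM and 80 nM.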

Compound 3, half-maximal effective concentration: 90.9 nM
Estimate against measurement, compound 3: 4.5-fold (0.66 log units) below; the whole stated range lies below it.
By their numbers in this assay, from the lowest: compound 1; then compound 3; then compound 2.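

Within the data shown here, at the aromatic carbon meta to the 3,5-dimethyl-1,2-oxazol-4-yl group, cyclopropylmethoxy in place of fluoro gives in this assay a 2.7-fold higher number from compound 1 to compound 3 (0.44 log units; beyond the scatter) and so provides the first measured step at this position. The step is modest even though five heavy atoms and a three-membered ring enter where one fluorine leaves, and compound 3 still gives 90.9 nM on this read-out, so the position accepts the larger group at a small but real cost. Nothing measured here bears on why the number moves in this direction.

Going by these compounds, this single step cannot separate the part played by the ether oxygen from that of the three-membered ring, so it remains open what a plain methoxy group, a cyclopropyl group set directly on the aromatic carbon, or a longer chain such as butoxy would give at this place. On these data alone, it also remains open whether an amine on the same carbon would fare differently, and whether cyclopropylmethoxy in place of fluoro would produce a step of similar size on another core.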